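Cyano for methyl on the aryl ring: compound 4

A few compounds are considered here, and "the series" means these few. Any claim that something is new, unique, unknown or untested is made for them only; others in the source may bear on it.

Compound 1 `Cc1ccc(-c2cs/c(=N/NC(=O)CSc3nnnn3-c3ccccc3)n2-c2ccccc2)cc1` gives 38.8% in a functional assay on C6 cells (Rattus norvegicus) for cytotoxicity, read by MTT assay, with a stated time of 24 h, tested at 25 ug/mL (a higher number here means a weaker effect of the compound at the concentration tested, a lower number a stronger effect), the lowest of the three numbers measured. Compound 2 `Cc1ccc(-c2cs/c(=N/NC(=O)CSc3ncccn3)n2-c2ccccc2)cc1` gives 82.7% and compound 3 `Cc1ccc(-c2cs/c(=N/NC(=O)CSc3nnc(C)s3)n2-c2ccccc2)cc1` gives 50.1%. Every measured step changes the group on the sulfur: a number 43.9 percentage points higher from compound 1 to compound 2 (beyond the scatter), a number 11.3 percentage points higher from compound 1 to compound 3 (beyond the scatter) and a number 32.6 percentage points lower from compound 2 to compound 3 (beyond the scatter). Compound 4 `N#Cc1ccc(-c2cs/c(=N/NC(=O)CSc3nnnn3-c3ccccc3)n2-c2ccccc2)cc1` differs from compound 1 at another place: cyano in place of methyl on an aromatic carbon. Within the data shown here, no measured step touches that ring, so the three steps give no direction for this change; the only anchor is compound 1 with 38.8%, and the width of the measured numbers sets the uncertainty. For compound 4 a step within the scatter is therefore expected, a number 3.2 percentage points higher from compound 1 to compound 4 (within the scatter). Compound 4 is estimated at 42%, in the range 25% to 62%.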

Compound 4, a percentage reported as activity, at one concentration (the size of the read-out at that concentration, not a potency): 64.2%
For compound 4 the middle estimate is 22.2 percentage points below the measured one; measured number above the stated range.
By their numbers in this assay, from the lowest: compound 1; then compound 3; then compound 4; then compound 2.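

In this assay, going from 4-methylphenyl to 4-cyanophenyl gives a number 25.4 percentage points higher from compound 1 to compound 4 (beyond the scatter). The aromatic ring carrying this group therefore also moves the read-out, so the group on the sulfur is not the only place that does, and here the cyano compound shows the weaker effect at the concentration tested. No measurement at hand accounts for this step.

From the compounds shown here alone, whether cyano in place of methyl acts the same way with pyrimidin-2-yl or 5-methyl-1,3,4-thiadiazol-2-yl on the sulfur stays open. So does the read-out with an amine or a carboxylic acid on that aromatic carbon.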